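A few compounds are considered here, and "the series" means these few. Any claim that something is new, unique, unknown or untested is made for them only; others in the source may bear on it.

Of the compounds shown here, two have been tested. Compound 1 `CC(C(=O)N1CCN(c2ccccc2)CC1)N1C(=O)CCC1=O` gives 50% in a functional assay on the whole organism (strain Swiss) with Mus musculus as the target, in the maximal electroshock model, with a stated time of 1 h, at a dose of 300 mg/kg by the intraperitoneal route; a lower number here means a weaker effect, a higher number a stronger effect of the compound at the dose given. Compound 2 `CCC(C(=O)N1CCN(c2ccccc2Cl)CC1)N1C(=O)CCC1=O`, which carries a longer chain and a 2-chlorophenyl group, gives 50% in this assay, so compound 2 stands level with compound 1 at the digits shown, the two values lying within the usual scatter of each other.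

Compound 3 `CCC(C(=O)N1CCN(c2cccc(F)c2)CC1)N1C(=O)CCC1=O` has not yet been measured. It differs from compound 2 in one place: 3-fluorophenyl in place of 2-chlorophenyl on an amine nitrogen in a ring. Among the compounds with values here, no step between measured compounds is available to guide the expectation, and the two measured values give no trend to extend. The step from compound 2 to compound 3 is therefore expected to be small, no change at the digits printed from compound 2 to compound 3 (within the scatter), and not beyond the scatter in either direction. Compound 3 is expected to reach 50% in this assay, with a range from 25% to 75%.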

Compound 3, a percentage reported as activity, at one dose (the size of the read-out at that dose, not a potency): 75%
Beside the measured number, compound 3's estimate is 25 percentage points below it; the measured number falls inside the stated range.
By their numbers in this assay, from the lowest: compounds 1 and 2 (each within the scatter of the next); then compound 3.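

Exchanging 2-chlorophenyl for 3-fluorophenyl on the amine nitrogen in a ring gives a number 25 percentage points higher from compound 2 to compound 3 (beyond the scatter) in this assay, so the group at this place can change the read-out at the dose given. Both groups count the same 7 heavy atoms and one six-membered aromatic ring of carbon only, yet they differ in two ways at once: which halogen the ring carries and where it sits. Nothing at hand explains the difference.

With both features changing in a single step, these compounds cannot show whether the halogen, its place on the ring, or the two together account for the rise. On these data alone, whether the read-out also responds to other groups on this phenyl ring, such as a methoxy group or a nitrile, remains open.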